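A few compounds are considered here, and "the series" means these few. Any claim that something is new, unique, unknown or untested is made for them only; others in the source may bear on it.

Measured in a functional assay on BXPC-3 cells (Homo sapiens) for inhibition, read by MTT assay; on this read-out higher numbers stand for weaker inhibition and lower numbers for stronger inhibition:
- compound 1 `COc1ccccc1NC(=O)c1cc2cnc(Nc3ccc(N4CCNCC4)cn3)nc2n1C1CCCC1` gives 4120 nM
- compound 2 `COc1ccc(NC(=O)c2cc3cnc(Nc4ccc(N5CCNCC5)cn4)nc3n2C2CCCC2)cc1` gives 8970 nM
- compound 3 `O=C(Nc1ccccc1Cl)c1cc2cnc(Nc3ccc(N4CCNCC4)cn3)nc2n1C1CCCC1` gives 4350 nM

Among these three, compound 2 has the highest number, 8970 nM, and so the weakest inhibition. Compound 4 `Cc1ccccc1NC(=O)c1cc2cnc(Nc3ccc(N4CCNCC4)cn3)nc2n1C1CCCC1` has not yet been measured. It has 2-methylphenyl in place of 4-methoxyphenyl on an amide-type nitrogen. Two measured steps change the group on this same nitrogen, and both are modest: a 2.2-fold higher number from compound 1 to compound 2 (0.34 log units; beyond the scatter) and a 2.1-fold lower number from compound 2 to compound 3 (0.31 log units; beyond the scatter). The swap of chloro for methoxy gave a 1.1-fold higher number from compound 1 to compound 3 (0.02 log units; within the scatter), so compound 1 and compound 3 cannot be told apart. Within the data shown here, no measured compound carries 2-methylphenyl, but compound 4 resembles compound 1 and compound 3 more closely than compound 2. A modest step towards a lower number, meaning stronger inhibition, is therefore expected in this assay. The expected change is a 2.1-fold lower number from compound 2 to compound 4 (0.32 log units; beyond the scatter). For compound 4 the estimated value is 4300 nM, with an expected range from 2400 nM to 7500 nM.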

Compound 4, half-maximal inhibitory concentration: 3340 nM
Estimate against measurement, compound 4: 1.3-fold (0.11 log units) above; low and high end bracket the measured number.
By their numbers in this assay, from the lowest: compounds 4, 1 and 3 (each within the scatter of the next); then compound 2.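

In this assay, 2-methylphenyl on the amide-type nitrogen joins 2-methoxyphenyl and 2-chlorophenyl as a third group giving stronger inhibition than 4-methoxyphenyl, with a 2.7-fold lower number from compound 2 to compound 4 (0.43 log units; beyond the scatter). The methyl compound cannot be told apart from the other two: a 1.3-fold lower number from compound 3 to compound 4 (0.11 log units; within the scatter) and a 1.2-fold lower number from compound 1 to compound 4 (0.09 log units; within the scatter) both lie within the scatter. Among these four compounds, exchanging methoxy, chloro and methyl within the 2-substituted phenyl groups therefore produces no readable change, and only compound 2, with its 4-methoxyphenyl group, stands apart.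

Nothing measured here explains this split. Going by these compounds, it remains open whether 4-methylphenyl would read like compound 2 or like compound 4, and how an unsubstituted phenyl or a 2-aminophenyl group would compare.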